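A few compounds are considered here, and "the series" means these few. Any claim that something is new, unique, unknown or untested is made for them only; others in the source may bear on it.

The set holds three measured compounds and one still to be measured. Compound 1 `Cc1noc(C)c1S(=O)(=O)N1CCC(N2CCC(C)CC2)CC1` and compound 3 `CC1CCN(C2CCN(S(=O)(=O)c3nccn3C)CC2)CC1` share their core with compound 2 `CC1CCN(C2CCN(S(=O)(=O)c3cccc(-c4ccc(F)cc4)c3)CC2)CC1`, differing only in the group on the sulfonyl sulfur. In a functional assay on DLD-1 cells (Homo sapiens) for antiproliferative activity, read by CellTiter-Glo, with a stated time of 72 h (on this read-out lower numbers stand for stronger inhibition and higher numbers for weaker inhibition), compound 2 gives 12 nM. Compound 1 gives only a limit of the assay, > 5000 nM. Compound 3 likewise gives only a limit, > 5000 nM. The step that the two limits leave unreadable from compound 1 to compound 3 therefore cannot be read in size or direction. Compound 2 thus stands as the only number shown, while the other two values are limits (the limit of > 5000 nM in this assay, at which 2 of the 3 values shown sit).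

Compound 4 `CC1CCN(C2CCN(S(=O)(=O)c3cccc(C(F)(F)F)c3)CC2)CC1` differs from compound 2 by trifluoromethyl in place of 4-fluorophenyl on an aromatic carbon. Within the data shown here, no measured step involves this part of the structure, so none bears directly on the change; the only guidance is that two of the three values sit at the limit (the limit of > 5000 nM in this assay, at which 2 of the 3 values shown sit), which makes a loss in this assay more likely than a gain. Compound 4 is expected to give 300 nM, in the range 40 nM to 3000 nM. This estimate amounts to an expected 25-fold higher number from compound 2 to compound 4 (1.40 log units; beyond the scatter), a step beyond the usual scatter.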

Compound 4, half-maximal inhibitory concentration: > 5000 nM
Compound 4: no number, only a limit; the forecaster's own chance of this, stated with the estimate: 25%; at least 16-fold (1.22 log units) between middle value and limit.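

Among these compounds, on an aromatic carbon of the six-membered aromatic ring, meta to a large group, trifluoromethyl in place of 4-fluorophenyl gives an at least 410-fold higher number from compound 2 to compound 4 (2.61 log units; beyond the scatter) in this assay, the first step in the set whose size can be read. The earlier compounds shown here differed only in the whole group on the sulfonyl sulfur, whereas this change shows that the number for compound 2 also depends on the 4-fluorophenyl at this position. Of the compounds shown, only compound 2 gives a number, and the others sit at the assay limit: the limit of > 5000 nM in this assay, at which 3 of the 4 values shown sit.

The compounds shown leave open whether a plain phenyl, a pyridyl or a longer chain at this carbon would keep a measurable number. They also leave open whether the fluorine of the 4-fluorophenyl contributes at all.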